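This account rests on a few compounds, and the source may have more. Where it says the series, first, only, none or still open, it means among the compounds named here.

Measured in a functional assay on HL-60 cells (Homo sapiens) for cytotoxicity, read by MTT assay, with a stated time of 72 h; a higher number here means a weaker inhibitor, a lower number a stronger inhibitor:
- compound 1 `O=C(Nc1nnc(-c2cccc(O)c2O)s1)c1ccc(Cl)cc1`: 9600 nM
- compound 2 `O=C(COc1ccccc1)Nc1nnc(-c2cccc(O)c2O)s1`: 11200 nM
- compound 3 `O=C(COc1ccccc1)Nc1nnc(-c2ccc(O)c(O)c2)s1`: 17400 nM

Compound 2, at 11200 nM, stands among these values with no gap beyond the scatter to either of the other two compounds. Compound 4 `O=C(Nc1nnc(-c2cccc(O)c2O)s1)c1ccccc1` has not yet been measured. It departs from compound 2 in a single place, with phenyl in place of phenoxymethyl on a carbonyl carbon.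

Among the measured compounds shown here, no measured step makes exactly this exchange, but one touches the same carbonyl carbon. That step, a 1.2-fold higher number from compound 1 to compound 2 (0.07 log units; within the scatter), is the closest evidence, and it is small. The other measured step, a 1.6-fold higher number from compound 2 to compound 3 (0.19 log units; within the scatter), concerns a different part of the molecule, on an aromatic carbon, so it bears on this question only as a further sign that the series has so far moved little in this assay. On these two steps, no change beyond the scatter is expected, and no direction can be favoured. The expected step is a 1.0-fold lower number from compound 2 to compound 4 (0.01 log units; within the scatter). For compound 4 the estimated value is 11000 nM, with an expected range from 5500 nM to 22000 nM.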

Compound 4, half-maximal inhibitory concentration: 20700 nM
Compound 4: middle estimate off by 1.9-fold (0.27 log units), on the low side, and the stated range covers the measured number.
By their numbers in this assay, from the lowest: compounds 1, 2, 3 and 4 (each within the scatter of the next, the first and the last beyond it).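

In this assay, the step of a 1.8-fold higher number from compound 2 to compound 4 (0.27 log units; within the scatter) shows that phenyl can stand in place of phenoxymethyl on this carbonyl carbon without a change beyond the scatter, even though phenoxymethyl is the larger group and the only one of the two that carries an oxygen. Among the compounds shown here, the step of a 2.2-fold higher number from compound 1 to compound 4 (0.33 log units; beyond the scatter) is new in kind: it is the first single exchange in this short series to pass the scatter, though only modestly, and it shows that the chloro on the aromatic ring of compound 1 counts for more here than the earlier steps had suggested, with compound 4 the weaker of that pair. Nothing available accounts for this difference between hydrogen and chloro.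

The compounds shown leave open whether the chloro step would hold on the 3,4-dihydroxyphenyl series of compound 3, or whether a bromo or a methoxy in place of the chloro would behave alike. They also say nothing about an amine or a carboxylic acid on the phenyl ring, or about a longer chain on the carbonyl carbon.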